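Cytotoxicity notes: methylpyridinyl ether regioisomer in the series

The source may hold more compounds than are shown below. What is called first, only, known or untested is meant among the compounds shown, and "the series" means these compounds.

Three compounds have readings in an ADME assay on PBMC cells (Homo sapiens) for cytotoxicity; a higher number here means that more compound is tolerated, a lower number that less compound is tolerated. Compound 1 `Cc1ccnc(OC(c2ccc(C(F)(F)F)cc2)C2CCN(C(C)CCNC(=O)c3c(Cl)cncc3Cl)CC2)c1` gives 33600 nM in this assay and shows the lowest of the three numbers. Compound 2 `CCO/N=C(/c1ccc(Br)cc1)C1CCN(C(C)(C)CCNC(=O)c2c(Cl)cncc2Cl)CC1` gives 34000 nM, which sits within the scatter of compound 1. Compound 3 `CCO/N=C(/c1ccc(Br)cc1)C1CCN(C(C)CNC(=O)c2c(C)cc[n+]([O-])c2C)CC1` gives 182000 nM, a number beyond the scatter above compound 1. For the measured compounds named here, no two measured compounds differ in one place, so no single step size is available.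

Compound 4 `Cc1cccc(OC(c2ccc(C(F)(F)F)cc2)C2CCN(C(C)CCNC(=O)c3c(Cl)cncc3Cl)CC2)n1` differs from compound 1 only in this way: 6-methylpyridin-2-yl in place of 4-methylpyridin-2-yl on an oxygen on a saturated carbon. Because compound 1 is read at 33600 nM and compound 2 at 34000 nM despite larger changes elsewhere, the step from the methylpyridinyl shift is expected to stay within the scatter of this assay, with no direction favoured. Compound 4 is estimated at 35000 nM in this assay, within 15000 nM to 80000 nM, a step of a 1.0-fold higher number from compound 1 to compound 4 (0.02 log units; within the scatter).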

Compound 4, half-maximal cytotoxic concentration: 6700 nM
Beside the measured number, compound 4's estimate is 5.2-fold (0.72 log units) above it; the measured number lies below the stated range.
By their numbers in this assay, from the lowest: compound 4; then compounds 1 and 2 (each within the scatter of the next); then compound 3.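

In this assay, the exchange of 4-methylpyridin-2-yl for 6-methylpyridin-2-yl gives a 5.0-fold lower number from compound 1 to compound 4 (0.70 log units; beyond the scatter). The earlier compounds shown here offered no pair differing in one place, and this pair shows that moving the methyl alone, with the same atoms joined differently, can shift the tolerated concentration beyond the scatter. No measurement shown speaks to the origin of this step.

Open, going by these compounds, is whether methoxy or an amine in place of the methyl would give a similar number. Also open, on these data alone, is whether the unsubstituted pyridin-2-yl ether would stand with compound 1 or compound 4.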